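Series notes: aminophenyl to pyridyl exchange at the carbonyl

A few compounds are considered here, and "the series" means these few. Any claim that something is new, unique, unknown or untested is made for them only; others in the source may bear on it.

Compound 1 `Nc1ccccc1C(=O)N/N=C/C1=C(Cl)c2ccccc2CCC1` and compound 2 `O=C(N/N=C/C1=C(Cl)c2ccccc2CCC1)c1cccnc1` share one core. In a functional assay on MDA-MB-231 cells (Homo sapiens) for inhibition, read by sulforhodamine B assay, with a stated time of 48 h (a higher number here means a weaker inhibitor of growth, a lower number a stronger inhibitor of growth), compound 1 gives 5000 nM and compound 2 gives 91700 nM. The change between them, (pyridin-3-yl in place of 2-aminophenyl on a carbonyl carbon), made an 18-fold higher number from compound 1 to compound 2 (1.26 log units; beyond the scatter). Compound 3 `Cc1cc2c(cc1C)C(Cl)=C(/C=N/NC(=O)c1ccccc1N)CCC2` carries a different core; the difference between the two cores is not broken down here. In this assay compound 3 gives 3700 nM, a number within the scatter of compound 1 and well apart from compound 2. Compound 4 `Cc1cc2c(cc1C)C(Cl)=C(/C=N/NC(=O)c1cccnc1)CCC2` is not yet measured. It differs from compound 3 by pyridin-3-yl in place of 2-aminophenyl on a carbonyl carbon, the same change as from compound 1 to compound 2, at a place described in identical words. For compound 4 the expected step is a 16-fold higher number from compound 3 to compound 4 (1.21 log units; beyond the scatter), resting on one earlier instance because an 18-fold higher number from compound 1 to compound 2 (1.26 log units; beyond the scatter) was seen on the other core. Within the data shown here, compound 4 is estimated at 60000 nM, with a range from 15000 nM to 200000 nM, kept wide since only one prior example of the change exists.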

Compound 4, concentration for 50% growth inhibition: 5400 nM
The estimate for compound 4 lay 11-fold (1.05 log units) above the measured number; the whole stated range lies above it.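

In this assay, pyridin-3-yl in place of 2-aminophenyl on a carbonyl carbon gives a 1.5-fold higher number from compound 3 to compound 4 (0.16 log units; within the scatter), so the size of the step did not carry over from one core to the other: the same change on two cores in this assay, an 18-fold higher number (1.26 log units; beyond the scatter) from compound 1 to compound 2 and a 1.5-fold higher number (0.16 log units; within the scatter) from compound 3 to compound 4, 13-fold (1.10 log units) apart, beyond the scatter of two such steps

Within these two pairs, the effect of the exchange depends on the core, and the step on one core is no guide to the step on the other. The pairs do not show which part of the difference between the cores matters, and they say nothing about any third core.

Open, as far as these compounds go, is where a plain phenyl on the carbonyl carbon would stand on either core. Such a group would separate the contribution of the amine from that of the ring nitrogen.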